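Swapping an octyloxy tail for a benzyloxy group

The compounds below may be only part of what the source reports. "The series", "measured", "known", "first", "only" and "open" are said of these compounds alone.

Measured so far:
compound 1 `CCCCOc1ccc(-c2[nH]c3ccccc3c2C2=C(Br)C(=O)NC2=O)cc1`: 3.87
compound 2 `CCCCCCCCOc1ccc(-c2[nH]c3ccccc3c2C2=C(Br)C(=O)NC2=O)cc1`: 5.21

Within the data shown here, compound 2 has the higher of the two numbers in a physicochemical assay for lipophilicity; on this read-out higher numbers stand for higher lipophilicity and lower numbers for lower lipophilicity: the step of a number 1.34 log units higher from compound 1 to compound 2 (beyond the scatter) shows that extending the chain raised lipophilicity considerably, and compound 2 therefore stands at the top of what has been measured, with compound 1 the only neighbour.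

Compound 3 `O=C1NC(=O)C(c2c(-c3ccc(OCc4ccccc4)cc3)[nH]c3ccccc23)=C1Br` keeps the shared core but changes the tail: phenyl in place of heptyl on a saturated chain carbon bound to an oxygen on an aromatic ring. Among the measured compounds shown here, the one measured step bears on this only indirectly: it tells how much a longer saturated chain adds, and compound 3 gives up most of that chain while taking on an aromatic ring in its place. Judged against compound 1, whose shorter chain gave 3.87, compound 3 is expected to land closer to compound 1 than to compound 2, so a clear drop from compound 2 is expected, a number 1.11 log units lower from compound 2 to compound 3 (beyond the scatter). On that basis, the value for compound 3 in this assay is estimated at 4.1, with a plausible range from 3.6 to 4.6.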

Compound 3, partition coefficient: 3.3
The estimate for compound 3 lay 0.80 log units above the measured number, and the stated range ends above it.
By their numbers in this assay, from the lowest: compound 3; then compound 1; then compound 2.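

The tail position responds to more than chain length, as the ring-bearing tail of compound 3 gives the lowest number of the three in this assay. Phenyl in place of heptyl gives a number 1.91 log units lower from compound 2 to compound 3 (beyond the scatter) even though the groups are close in heavy-atom count, 6 carbon entering and 7 carbon leaving, and phenyl in place of propyl gives a number 0.57 log units lower from compound 1 to compound 3 (beyond the scatter) at the same place, on a saturated chain carbon bound to an oxygen on an aromatic ring. So across these three compounds, the read-out depends on what kind of group sits at the end of the tail as well as how large it is, but no supporting measurement is available to explain why.

The compounds shown leave open whether a cyclohexyl group in place of the phenyl would give a number near those of the chains or near that of compound 3, which would help separate the effect of an aromatic ring from that of any ring. They also leave open how a pyridine ring, with nitrogen in the ring, or an amine on the tail would behave at this position.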